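This account rests on a few compounds, and the source may have more. Where it says the series, first, only, none or still open, it means among the compounds named here.

Measured in a functional assay on K562 cells (Homo sapiens) for antiproliferative activity, read by CCK-8 assay, with a stated time of 72 h; a higher number here means a weaker inhibitor of growth, a lower number a stronger inhibitor of growth:
- compound 1 `CCC1C(=O)N(C)c2cnc(Nc3ccc(S(=O)(=O)NCC(C)C)cc3)nc2N1c1ccn(C)n1`: 7300 nM
- compound 2 `CCC1C(=O)N(C)c2cnc(-n3ccc4cc(C(=O)NC)ccc43)nc2N1c1ccn(C)n1`: 13300 nM

Compound 2 stands within the scatter of compound 1, so these two values cannot be told apart. Compound 3 `CCCCNC(=O)c1ccc2c(ccn2-c2ncc3c(n2)N(c2ccn(C)n2)C(CC)C(=O)N3C)c1` differs from compound 2 by propyl in place of hydrogen on a saturated chain carbon bound to an amide-type nitrogen, or methylcarbamoyl to butylcarbamoyl. Among the measured compounds shown here, no measured step covers this change, so the expectation starts from compound 2 at 13300 nM. The expected 1.5-fold lower number from compound 2 to compound 3 (0.17 log units; within the scatter) in this assay is small, leans towards a lower number and stays within the scatter. For compound 3 the estimate is 9000 nM, with an expected range of 3500 nM to 22000 nM.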

Compound 3, concentration for 50% growth inhibition: 14100 nM
Compound 3: the middle estimate sits 1.6-fold (0.19 log units) below what was measured, within the range that was stated.
By their numbers in this assay, from the lowest: compounds 1, 2 and 3 (each within the scatter of the next).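

In this assay, methylcarbamoyl to butylcarbamoyl, with propyl in place of hydrogen on a saturated chain carbon bound to an amide-type nitrogen, gives a 1.1-fold higher number from compound 2 to compound 3 (0.03 log units; within the scatter). At this position, compound 2 and compound 3 cannot be told apart, so adding propyl here does not separate them in this read-out. Nothing measured explains this result.

As far as these compounds go, whether a longer chain, an amine or a carboxylic acid in place of propyl would separate from compound 2 remains open.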